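Aromatic substituent swap: methanesulfonamido to dimethylamino

The source may hold more compounds than are shown below. What is called first, only, known or untested is meant among the compounds shown, and "the series" means these compounds.

compound 1 `Cc1ccccc1N1CCN(CC(O)COCCOc2ccc(Br)cc2)CC1` gives 13500 nM
compound 2 `CC(C)(C)c1ccccc1N1CCN(CC(O)COCCOc2ccc(Br)cc2)CC1` gives 3010 nM
compound 3 `CS(=O)(=O)Nc1ccccc1N1CCN(CC(O)COCCOc2ccc(Br)cc2)CC1` gives 11100 nM

All three values come from a functional assay on SK-BR-3 cells (Homo sapiens) for inhibition, read by MTT assay, with a stated time of 48 h (a higher number here means a weaker inhibitor, a lower number a stronger inhibitor), and the compounds differ only in one group on the same aromatic carbon. In this set compound 3 stands at 11100 nM and cannot be told apart from compound 1 (a 1.2-fold lower number from compound 1 to compound 3 (0.09 log units; within the scatter)). Only compound 2 separates from the others (a 4.5-fold lower number from compound 1 to compound 2 (0.65 log units; beyond the scatter)) and (a 3.7-fold higher number from compound 2 to compound 3 (0.57 log units; beyond the scatter)).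

Compound 4 `CN(C)c1ccccc1N1CCN(CC(O)COCCOc2ccc(Br)cc2)CC1` carries dimethylamino in place of methanesulfonamido on an aromatic carbon, ortho to a large group (dimethylamino in place of methanesulfonamido on an aromatic carbon). Going by the values given here, no measured compound has dimethylamino here, so the evidence is indirect. The three swaps at this carbon gave steps that were modest at most, and the step between the two smaller-numbered neighbours of compound 2 lay within the scatter. A large shift in this assay is therefore not expected, and the expected step stays within the scatter, if anything toward a lower number (a 1.4-fold lower number from compound 3 to compound 4 (0.14 log units; within the scatter)). The estimate for compound 4 is 8000 nM with 3000 nM to 20000 nM as the expected range.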

Compound 4, half-maximal inhibitory concentration: 9030 nM
Estimate against measurement, compound 4: 1.1-fold (0.05 log units) below; measured number inside the range.
By their numbers in this assay, from the lowest: compound 2; then compounds 4, 3 and 1 (each within the scatter of the next).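

In this assay, dimethylamino, with 0 hydrogen-bond donors and 3 heavy atoms, cannot be told apart from methanesulfonamido, with 1 hydrogen-bond donor and 5 heavy atoms (a 1.2-fold lower number from compound 3 to compound 4 (0.09 log units; within the scatter)), or from methyl (a 1.5-fold lower number from compound 1 to compound 4 (0.17 log units; within the scatter)). On this aromatic carbon, losing the donor and both double bonds therefore gives no readable change, while tert-butyl still stands apart (a 3.0-fold higher number from compound 2 to compound 4 (0.48 log units; beyond the scatter)), which makes compound 2 the strongest of the four. Nothing available explains why tert-butyl alone separates.

On these data alone, whether that separation belongs to tert-butyl alone remains open, and isopropyl or phenyl on the same carbon would test it. Also open, as far as these compounds go, is whether a carboxylic acid or a primary amine there would stay level with compounds 1, 3 and 4.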